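Swapping chloro for methoxy on a cytotoxic core

This account rests on a few compounds, and the source may have more. Where it says the series, first, only, none or still open, it means among the compounds named here.

In a functional assay on A549 cells (Homo sapiens) for cytotoxicity (a lower number here means that less compound is needed, a higher number that more compound is needed for the effect), the compounds measured so far are these:
- compound 1 `Oc1ccc2nc(-c3ccccc3)cc(O)c2c1` gives 8.14 ug/mL
- compound 2 `Oc1cc(-c2ccccc2)nc2ccc(Cl)cc12` gives 0.51 ug/mL
- compound 3 `Oc1ccc2c(O)cc(-c3ccccc3)nc2c1` gives 0.81 ug/mL

Compound 2 sits at the low end of these numbers, so little of it is needed for the effect. Its value and that of compound 3 lie within the usual scatter of each other, while compound 1 stands well apart from compound 2.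

The next compound to be tested is compound 4 `COc1ccc2nc(-c3ccccc3)cc(O)c2c1`, which has methoxy in place of chloro on an aromatic carbon when set against compound 2.

Within the data shown here, only one measured step bears on this change: a 16-fold lower number from compound 1 to compound 2 (1.20 log units; beyond the scatter), with chloro in place of hydroxy on that same carbon. That step was large, so this carbon clearly matters in this assay. Methoxy, like hydroxy, has an oxygen, so some return towards the higher number of compound 1 (8.14 ug/mL) seems likely. Among the measured compounds shown here, no methoxy compound has been measured, however, so a full return is not assumed and the size stays uncertain.

The expected change is a 4.9-fold higher number from compound 2 to compound 4 (0.69 log units; beyond the scatter), part of the way back. Compound 4 is estimated at 2.5 ug/mL, with an expected range from 0.7 ug/mL to 9 ug/mL as the likely span.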

Compound 4, half-maximal effective concentration: 0.19 ug/mL
The estimate for compound 4 lay 13-fold (1.12 log units) above the measured number; the measured number lies below the stated range.
By their numbers in this assay, from the lowest: compound 4; then compounds 2 and 3 (each within the scatter of the next); then compound 1.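

In this assay, having an oxygen on this aromatic carbon does not by itself keep the number high: placing a methyl on the hydroxy oxygen gives a 43-fold lower number from compound 1 to compound 4 (1.63 log units; beyond the scatter) and removes most of the gap seen with the free hydroxy group. Chloro is also not the only group on this carbon that goes with a low number, since methoxy in place of chloro gives a 2.7-fold lower number from compound 2 to compound 4 (0.43 log units; beyond the scatter) and so reaches the lowest number of the series, beyond the scatter from compound 2 and well below compound 1. Nothing available here explains why methoxy and chloro both give much lower numbers than hydroxy on this carbon, or why methoxy gives the lower number of the two.

Going by these compounds, it remains open whether a longer chain on the same oxygen, such as ethoxy, would lower the number further or raise it again, and how an amine on this carbon would compare. The rest of the shared core is identical in compound 1, compound 2 and compound 4, so these compounds say nothing about how changes elsewhere would combine with methoxy.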